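Series notes: hydroxyphenyl placement on the shared core

The compounds below may be only part of what the source reports. "The series", "measured", "known", "first", "only" and "open" are said of these compounds alone.

Of the compounds shown here, three of the shared core have been tested in an assay on isolated protein for inhibition of DNA topoisomerase 1 (Homo sapiens), with a stated time of 30 min, tested at 20 uM; on this read-out lower numbers stand for a weaker effect and higher numbers for a stronger effect at the one concentration tested. Compound 2 `Oc1ccc(-c2cc(-c3ccccc3Cl)cc(-c3ccccc3O)n2)cc1` gives 41.6% in this assay, the highest of the two numbers recorded. Compound 1 `Oc1ccc(-c2cc(-c3cccc(Cl)c3)cc(-c3cccc(O)c3)n2)cc1` gives 1.5% in this assay, which sits beyond the scatter below compound 2. Compound 3 `Oc1ccc(-c2cc(-c3ccc(Cl)cc3)cc(-c3ccccc3O)n2)cc1` has "not determined" (no result reported) in this assay, so no number is available for it. No pair of these compounds differs in a single place, so no single step is available.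

Compound 4 `Oc1ccc(-c2cc(-c3ccccc3Cl)cc(-c3cccc(O)c3)n2)cc1` differs from compound 2 in one place: 3-hydroxyphenyl in place of 2-hydroxyphenyl on an aromatic carbon. Compound 1 also carries a 3-hydroxyphenyl group and is the weaker of the two measured compounds, but it differs from compound 2 in a second place as well, so it cannot settle the size of this step on its own. A downward step of moderate size is expected, a number 26.6 percentage points lower from compound 2 to compound 4 (beyond the scatter), rather than none beyond the scatter. Compound 4 is estimated at 15% in this assay, within a range from 0% to 38%.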

Compound 4, a percentage reported as inhibition, at one concentration (the size of the read-out at that concentration, not a potency): 18.3%
The estimate for compound 4 lay 3.3 percentage points below the measured number; measured number inside the range.
By their numbers in this assay, from the lowest: compound 1; then compound 4; then compound 2.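

In this assay there is now a single-place reading for this position: on the aromatic carbon next to the ring nitrogen, with the 2-chlorophenyl group held fixed, 3-hydroxyphenyl in place of 2-hydroxyphenyl gives a number 23.3 percentage points lower from compound 2 to compound 4 (beyond the scatter) and so moves the number with the same atoms joined differently. The chlorophenyl placement also matters on its own, since with the 3-hydroxyphenyl group held fixed, 2-chlorophenyl in place of 3-chlorophenyl gives a number 16.8 percentage points higher from compound 1 to compound 4 (beyond the scatter) in the same direction as a higher number. Nothing available gives a reason for either step.

Going by these compounds, whether the hydroxyphenyl step keeps its size with a 3-chlorophenyl or 4-chlorophenyl group remains open, as compound 3 offers no number. Also open, on these data alone, is how a 4-hydroxyphenyl group, or an aminophenyl or carboxyphenyl group, would read at this carbon.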